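Compound 4: a bromo step from the limit

The source may hold more compounds than are shown below. What is called first, only, known or untested is meant among the compounds shown, and "the series" means these compounds.

Three compounds have been measured in a functional assay on HT-29 cells (Homo sapiens) (on this read-out lower numbers stand for stronger inhibition of growth and higher numbers for weaker inhibition of growth), so far:
- Compound 1 `O=S(=O)(/C=C/c1ccccc1)Cc1ccc(Nc2ncnc3ccccc23)cc1` gives > 100000 nM as a limit
- Compound 2 `N#Cc1ccc(/C=C/S(=O)(=O)Cc2ccc(Nc3ncnc4ccccc34)cc2)cc1` gives > 100000 nM as a limit
- Compound 3 `O=S(=O)(/C=C/c1ccc(F)cc1F)Cc1ccc(Nc2ncnc3ccccc23)cc1` gives > 100000 nM as a limit

Compound 3 has no number of its own in this assay and stands only at a limit. For the measured compounds named here, the series shares one place so far, the limit of > 100000 nM in this assay, at which 3 of the 3 values shown sit, and nothing yet separates its members.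

Compound 4 `O=S(=O)(/C=C/c1ccc(F)cc1F)Cc1ccc(Nc2ncnc3ccc(Br)cc23)cc1` carries bromo in place of hydrogen on an aromatic carbon in the shared core. The measured steps a step that the two limits leave unreadable from compound 1 to compound 2 and a step that the two limits leave unreadable from compound 1 to compound 3 and a step that the two limits leave unreadable from compound 2 to compound 3 bear on it only loosely. None of them touches the carbon where bromo enters, and none has a readable size. No size can therefore be carried over, and only a modest shift towards stronger inhibition of growth is expected, with a further limit quite possible. The expected step is an at least 1.6-fold lower number from compound 3 to compound 4 (0.22 log units; that floor lies within the scatter) and it remains a rough estimate. Compound 4 is estimated at 60000 nM with an expected range from 10000 nM to 100000 nM if a number is reported at all.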

Compound 4, concentration for 50% growth inhibition: 100000 nM
Estimate against measurement, compound 4: 1.7-fold (0.22 log units) below; low and high end bracket the measured number.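

In this assay, bromo in place of hydrogen on an aromatic carbon of the shared core gives a number no higher from compound 3 to compound 4 (the limit leaves the size open), and the size of this step cannot be read. Compound 4 gives 100000 nM, a number and not a limit, which sets it apart from the other members of the series: the limit of > 100000 nM in this assay, at which 3 of the 4 values shown sit. This carbon is therefore the first place in the series where a change has brought a reported number, though that number does not show how far bromo moves the read-out.

On these data alone, whether bromo on the same carbon would also bring a number to compound 1 or compound 2 remains open. As far as these compounds go, it is equally open what an amine, a methoxy group or a carboxylic acid on this carbon would give, and whether any group there reaches clearly lower numbers.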